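The compounds below may be only part of what the source reports. "The series", "measured", "known", "first", "only" and "open" are said of these compounds alone.

Measured so far:
- compound 1 `Cc1c(-c2ccccc2)sc(N)c1C(=O)c1ccc(Cl)cc1`: 1%
- compound 2 `CC(C)(C)Cc1csc(N)c1C(=O)c1cccc(Cl)c1`: 8%
- compound 3 `CC(C)(C)Cc1c(-c2cccc(F)c2F)sc(N)c1C(=O)c1ccc(Cl)cc1`: 1%

In an assay on CHO cells for displacement of a labelled ligand from adenosine receptor A3 (Homo sapiens), read by scintillation counting, tested at 10 uM (a lower number here means less inhibition, a higher number more inhibition at the concentration tested (going by the name of the read-out)), compound 3 gives 1%, the same number at the digits shown as compound 1, and together these two are the lowest of the three values. Compound 2 gives 8%, which differs from compound 3 only within the usual scatter. All three compounds therefore show little inhibition at the tested concentration.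

Compound 4 `COc1ccccc1-c1sc(N)c(C(=O)c2ccc(Cl)cc2)c1CC(C)(C)C` has not been measured. Compared with compound 3 it carries 2-methoxyphenyl in place of 2,3-difluorophenyl on an aromatic carbon. Within the data shown here, no step between two measured compounds is available, so no change can be read from the data for such a swap. Given that every measured compound gives a low value, compound 4 is expected to stay at that level, with a step of a number 3 percentage points higher from compound 3 to compound 4 (within the scatter) from compound 3, not beyond the scatter. The estimate for compound 4 is 4%, between 0% and 15%.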

Compound 4, a percentage reported as inhibition, at one concentration (the size of the read-out at that concentration, not a potency): 1%
Beside the measured number, compound 4's estimate is 3 percentage points above it; the range from low to high includes it.
By their numbers in this assay, from the lowest: compounds 1, 3, 4 and 2 (each within the scatter of the next).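

In this assay, 2-methoxyphenyl in place of 2,3-difluorophenyl on this aromatic carbon, next to the ring sulfur, gives no change at the digits printed from compound 3 to compound 4 (within the scatter). Among these compounds, this is the first direct comparison at this position, and it shows that this swap, which brings in a hydrogen-bond acceptor, leaves the reading low. Nothing at hand explains this result. Still open, on these data alone, is whether an amine, a carboxylic acid or a longer chain at this position would give clearly more inhibition. Also open, as far as these compounds go, is whether a group other than neopentyl on the neighbouring ring atom would change the picture.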